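A few compounds are considered here, and "the series" means these few. Any claim that something is new, unique, unknown or untested is made for them only; others in the source may bear on it.

Compound 1 `C=CCOc1cc(/C=C/C(=O)c2ccc(OC)c3c2OC(C)(C)C=C3)ccc1OC` and compound 2 `COc1ccc(/C=C/C(=O)c2ccc(OC)c3c2OC(C)(C)C=C3)cc1OC(=O)CCl` share one core and differ on an oxygen on an aromatic ring. In an ADME assay on L02 cells (Homo sapiens) for cytotoxicity, read by MTT assay (on this read-out lower numbers stand for stronger inhibition and higher numbers for weaker inhibition), compound 1 gives > 20000 nM, which is a limit of the assay rather than a number. In this assay compound 2 gives > 10000 nM, again a limit and not a number. The step that the two limits leave unreadable from compound 1 to compound 2 therefore cannot be sized, since both values sit at limits, one at the limit of > 10000 nM in this assay, at which 1 of the 2 values shown sits, and the other at the limit of > 20000 nM in this assay, at which 1 of the 2 values shown sits. Compound 3 `COc1ccc(/C=C/C(=O)c2ccc(OC)c3c2OC(C)(C)C=C3)cc1OS(=O)(=O)Cc1ccccc1` carries the change (benzylsulfonyl in place of (chloromethyl)carbonyl on an oxygen on an aromatic ring). Among the measured compounds shown here, no measured step can be read as a guide for this change, so the only hint is that compound 2 shows weak inhibition in this assay. Compound 3 is expected to stay weak as well, with an estimated step that the limit leaves unreadable from compound 2 to compound 3. The estimate for compound 3 in this assay is 20000 nM, within a range of 8000 nM to 50000 nM.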

Compound 3, half-maximal inhibitory concentration: > 10000 nM
Compound 3: only a limit was reported (the forecaster's own chance of this, stated with the estimate: 75%); the middle value does not contradict the limit.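

In this assay compound 3 gives only a limit, as do compound 1 and compound 2, so no step among the three can be read: the limit of > 10000 nM in this assay, at which 2 of the 3 values shown sit.

The compounds shown leave open how allyl, (chloromethyl)carbonyl and benzylsulfonyl on this oxygen truly compare, with no actual number for any of them.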